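The source may hold more compounds than are shown below. What is called first, only, known or untested is meant among the compounds shown, and "the series" means these compounds.

Working notes on the series.

Compound 1 `C[C@@H]1CN(c2sc(C(F)(F)F)nc2-c2nc3ccccc3[nH]2)CCN1C(=O)Cn1cc(Cl)cn1` gives, in a functional assay on Venous blood for antagonist activity at C-X-C chemokine receptor type 3 (Homo sapiens), read by flow cytometry, with a stated time of 30 min, in the presence of a further agent that is not named here (a lower number here means a stronger inhibitor, a higher number a weaker inhibitor), a value of 251 nM. Among the three compounds measured so far it stands second highest. Compound 3 `Cc1nc(C)n(CC(=O)N2CCN(c3sc(C(F)(F)F)nc3-c3nc4cccc(C)c4[nH]3)C[C@H]2C)n1` gives 376 nM in this assay, and the gap between compound 1 and compound 3 lies within the scatter, so no order between the two is claimed. Going by the values given here, compound 2 `Cc1nc(C)n(CC(=O)N2CCN(c3sc(C(F)(F)F)nc3-c3nc4ccc(C5CCN(C)CC5)cc4[nH]3)C[C@H]2C)n1` gives 84.7 nM in this assay, a lower number than compound 1 by more than the scatter; compound 2 differs from compound 1 in more than one place, so no single step is drawn from that pair.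

Compound 4 `C[C@@H]1CN(c2sc(C(F)(F)F)nc2-c2nc3ccccc3[nH]2)CCN1C(=O)Cn1cnc2cccnc21` has not yet been measured. It differs from compound 1 in one place: a group of 9 heavy atoms (6 carbon, 3 nitrogen; one five-membered aromatic ring with 2 hetero atoms, one six-membered aromatic ring with 1 hetero atom) in place of a group of 6 heavy atoms (3 carbon, 2 nitrogen, 1 chlorine; one five-membered aromatic ring with 2 hetero atoms), on a saturated chain carbon bound to a carbonyl carbon.

Among the compounds with values here, no measured pair isolates this change, so the expectation rests on compound 1 alone. The step from compound 1 to compound 4 in this assay is expected to be small, a 1.2-fold higher number from compound 1 to compound 4 (0.08 log units; within the scatter), with no clear direction beyond the scatter. Compound 4 is estimated at 300 nM in this assay, with a range from 120 nM to 750 nM.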

Compound 4, half-maximal inhibitory concentration: 70 nM
Compound 4: middle estimate off by 4.3-fold (0.63 log units), on the high side; measured number outside the range, below it.
By their numbers in this assay, from the lowest: compounds 4 and 2 (each within the scatter of the next); then compounds 1 and 3 (each within the scatter of the next).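

In this assay the group on the saturated chain carbon bound to a carbonyl carbon proves able to move the number, with a 3.6-fold lower number from compound 1 to compound 4 (0.55 log units; beyond the scatter) on replacing the 4-chloro-1H-pyrazol-1-yl group by the group with two aromatic rings. This one step removes the chlorine and adds a six-membered aromatic ring with 1 hetero atom at the same time, so it does not separate the two changes. No measurement at hand accounts for the step.

On these data alone, whether the chlorine or the added ring carries the step stays open, as does the effect of a plain pyrazole, a phenyl ring or an open-chain amine at this place. Also open, as far as these compounds go, is whether the same exchange carries over to the cores of compound 2 and compound 3.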